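The source may report more compounds than this note shows. Statements on the series, on what has been measured and on what is new or still open speak of the compounds shown alone.

Compound 1 `Nc1ncnc2c1c(-c1cnc3[nH]ccc3c1)nn2CCCC(=O)NO` carries a hydroxycarbamoyl chain on its core. In a functional assay on MDA-MB-231 cells (Homo sapiens) for inhibition, read by MTT assay, with a stated time of 72 h (on this read-out lower numbers stand for stronger inhibition and higher numbers for weaker inhibition), compound 1 reaches only a limit, > 150000 nM, so no number stands for it; the limit of > 150000 nM in this assay, at which 1 of the 2 values shown sits, marks where it sits. Compound 2 `Nc1nc2cc(-c3nn(CCCCCCCCCC(=O)NO)c4ncnc(N)c34)ccc2o1` is the other measured compound, with a far longer chain on a different core. In this assay compound 2 also stops at a limit, > 50000 nM, as the limit of > 50000 nM in this assay, at which 1 of the 2 values shown sits, records. Among the measured compounds shown here, no pair of measured compounds differs in a single place, so compound 1 is placed only by these two limits, with no measured step to set a scale. Compound 3 `Nc1ncnc2c1c(-c1cnc3[nH]ccc3c1)nn2CCCCCC(=O)NO` has not yet been measured in this assay. It differs from compound 1 by 2-(hydroxycarbamoyl)ethyl in place of hydroxycarbamoyl on a saturated chain carbon, three bonds along the chain from an aromatic nitrogen. Without a measured step to lean on, the expected change is a modest move toward stronger inhibition, one that may not clear the scatter. Compound 3 is expected to give 30000 nM, between 5000 nM and 150000 nM. That estimate means an expected step of an at least 5.0-fold lower number from compound 1 to compound 3 (0.69 log units; beyond the scatter). From the compounds shown here alone, whether a number or again only a limit is reported remains open.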

Compound 3, half-maximal inhibitory concentration: > 100000 nM
Compound 3 was reported as a limit (the forecaster's own chance of this, stated with the estimate: 40%); middle value at least 3.3-fold (0.52 log units) away from the limit.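

In this assay compound 3 also stops at a limit, > 100000 nM. Among the compounds shown here, compound 1 likewise has only a limit, so no step from compound 1 to compound 3 can be read. The compounds shown carry limits only, which leaves open whether 2-(hydroxycarbamoyl)ethyl in place of hydroxycarbamoyl changes inhibition at all.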